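A few compounds are considered here, and "the series" means these few. Any claim that something is new, unique, unknown or untested is made for them only; others in the source may bear on it.

Working notes on the series. Among the compounds with values here, compound 2 `COCOc1cc(C(C)(C)C)ccc1C/N=C(\S)NCc1ccc(NS(C)(=O)=O)cc1` stands at the higher end of the two numbers so far: in a functional assay for inhibition of Vanilloid receptor (Rattus norvegicus) (a lower number here means a stronger inhibitor, a higher number a weaker inhibitor), compound 2 gives 500 nM, while compound 1 `CCCCOc1cc(C(C)(C)C)ccc1C/N=C(\S)NCc1ccc(NS(C)(=O)=O)cc1` gives 60 nM in this assay. Within the data shown here, the one step measured so far, an 8.3-fold higher number from compound 1 to compound 2 (0.92 log units; beyond the scatter), shows that this assay responds to what sits on the oxygen-bearing carbon of the core, with the shorter group giving the weaker inhibitor. Compound 3 `CC(=O)OCc1cc(C(C)(C)C)ccc1C/N=C(\S)NCc1ccc(NS(C)(=O)=O)cc1` differs from compound 2 by acetoxymethyl in place of methoxymethoxy on an aromatic carbon. Among the measured compounds shown here, no measured step covers this exchange, so the only guide is the sensitivity at this position seen in the step from compound 1 to compound 2. The expectation for compound 3 is therefore a modest change, direction uncertain, with the step of a 1.7-fold lower number from compound 2 to compound 3 (0.22 log units; within the scatter) staying small. Compound 3 is estimated at 300 nM in this assay, within 60 nM to 1500 nM.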

Compound 3, half-maximal inhibitory concentration: 580 nM
Beside the measured number, compound 3's estimate is 1.9-fold (0.29 log units) below it, and the stated range covers the measured number.
By their numbers in this assay, from the lowest: compound 1; then compounds 2 and 3 (each within the scatter of the next).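

In this assay, acetoxymethyl and methoxymethoxy are not told apart on this aromatic carbon: a 1.2-fold higher number from compound 2 to compound 3 (0.06 log units; within the scatter). The exchange adds a double bond outside the aromatic rings and attaches the group through carbon rather than oxygen, yet the read-out does not separate the two groups, while butoxy stays apart from both, with an 8.3-fold higher number from compound 1 to compound 2 (0.92 log units; beyond the scatter) and a 9.7-fold higher number from compound 1 to compound 3 (0.99 log units; beyond the scatter). No measurement at hand accounts for this.

Within the data shown here, the three compounds do not separate the length of the chain from the nature of the group, since butoxy is the only simple alkyl ether among them and the only group giving the lower number. Left open is how a methoxy or ethoxy group, a longer chain such as hexyloxy, or a hydroxymethyl or aminomethyl group would read at this position.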